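The compounds below may be only part of what the source reports. "The series", "measured", "known", "first", "only" and "open" are said of these compounds alone.

Measured compounds:
- compound 1, `C=CCn1c(=O)/c(=C\c2ccccc2OC)[nH]c(=O)/c1=C\c1ccccc1OC`: 21500 nM
- compound 2, `C=CCn1c(=O)/c(=C\c2ccc(C)cc2)[nH]c(=O)/c1=C\c1ccccc1OC`: "not active" (no number reported)

In a functional assay on NCI-H1975 cells (Homo sapiens) for cytotoxicity, read by CCK-8 assay, with a stated time of 72 h (a higher number here means a weaker inhibitor, a lower number a stronger inhibitor), compound 1 gives 21500 nM. In this assay compound 2 gives "not active" (no number reported), so no number stands for compound 2; it is reported only as showing no measurable effect, and it cannot be placed on a scale against compound 1. Compound 3, `C=CCn1c(=O)/c(=C\c2ccccc2F)[nH]c(=O)/c1=C\c1ccccc1OC`, has not yet been tested. It differs from compound 2 in one place: 2-fluorophenyl in place of 4-methylphenyl on a double-bonded chain carbon bound to an aromatic carbon. Since compound 2 has no number, no size can be put on a step from compound 2 to compound 3; if compound 3 yields a number at all, that is already a move toward stronger inhibition. Compound 3 is expected to land near the weak value of compound 1, 21500 nM, with a real chance that it too is reported as inactive. The estimate for compound 3 in this assay is 30000 nM, expected to fall between 8000 nM and 100000 nM.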

Compound 3, half-maximal inhibitory concentration: 25100 nM
The estimate for compound 3 lay 1.2-fold (0.08 log units) above the measured number; the range from low to high includes it.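

In this assay compound 3 gives a readable 25100 nM, while compound 2, which carries 4-methylphenyl at the same place, has no number, so the step between these two cannot be read. Fluoro in place of methoxy on an aromatic carbon gives a 1.2-fold higher number from compound 1 to compound 3 (0.07 log units; within the scatter), so the two compounds cannot be told apart in this test. Nothing measured here explains either result.

The compounds shown leave open whether any group on this aromatic ring can give a clearly lower number, for example an amine or a carboxylic acid in place of the fluoro. They also leave open whether the methyl group itself, or where it sits on the ring, accounts for compound 2 having no number.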